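A few compounds are considered here, and "the series" means these few. Any claim that something is new, unique, unknown or untested is made for them only; others in the source may bear on it.

Compound 2 `COc1cc(OC)cc(C(=O)Nc2cccc(-c3oc4cc(-c5ccc(F)cc5)ccc4c(=O)c3O)c2)c1` and compound 1 `CCc1ccc(C(=O)Nc2cccc(-c3oc4cc(-c5ccc(F)cc5)ccc4c(=O)c3O)c2)cc1` share one core and differ only in the aromatic group attached to the amide carbonyl. In a functional assay on GTL 16 cells for antiproliferative activity against GTL 16 cell line (Homo sapiens), read by CCK-8 assay, with a stated time of 72 h (on this read-out lower numbers stand for stronger inhibition and higher numbers for weaker inhibition), compound 2 gives 19600 nM, while compound 1 gives 24600 nM; the two numbers lie within the usual scatter of each other, so no real order between them can be claimed. Among the compounds with values here, the single comparison available, a 1.3-fold lower number from compound 1 to compound 2 (0.10 log units; within the scatter), shows that exchanging one aromatic group for another at this carbonyl carbon left the read-out essentially unchanged.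

Compound 3 `O=C(Nc1cccc(-c2oc3cc(-c4ccc(F)cc4)ccc3c(=O)c2O)c1)c1ccc(Cl)nc1` is not yet measured. It differs from compound 2 by 6-chloropyridin-3-yl in place of 3,5-dimethoxyphenyl on a carbonyl carbon. This is again an exchange of the aromatic group on the carbonyl carbon, the same kind of change that gave only a 1.3-fold lower number from compound 1 to compound 2 (0.10 log units; within the scatter). On that basis the step is expected to stay within the scatter, with a 1.0-fold higher number from compound 2 to compound 3 (0.01 log units; within the scatter) as the estimated change. For compound 3 the expected value in this assay is therefore 20000 nM, with a likely range from 8000 nM to 50000 nM.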

Compound 3, half-maximal inhibitory concentration: 7520 nM
Compound 3: the middle estimate sits 2.7-fold (0.42 log units) above what was measured, outside the stated range (below it).
By their numbers in this assay, from the lowest: compound 3; then compounds 2 and 1 (each within the scatter of the next).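

The position on the carbonyl carbon proves able to move the read-out, which the exchange of 4-ethylphenyl for 3,5-dimethoxyphenyl did not show. In this assay the entry of 6-chloropyridin-3-yl gives a 2.6-fold lower number from compound 2 to compound 3 (0.42 log units; beyond the scatter) and, against the other aromatic group, a 3.3-fold lower number from compound 1 to compound 3 (0.51 log units; beyond the scatter) so compound 3 stands lowest of the three, with both steps beyond the scatter yet modest in size. The change is also the first here to bring a ring hetero atom and a chlorine into this place, with fewer heavy atoms than 3,5-dimethoxyphenyl, but no measurement is available that would explain the lower number.

Since the ring nitrogen and the chlorine enter together, the compounds shown cannot tell which of them, or whether only their combination, goes with the lower number, a question that a plain pyridin-3-yl and a 4-chlorophenyl on the same carbonyl would separate. Going by these compounds, it also remains open whether an amine, a methoxy group or a carboxylic acid in place of the chlorine would keep, extend or lose this modest gain.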